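Fluoro in place of chloro: an expected small step

The compounds below may be only part of what the source reports. "The series", "measured", "known", "first", "only" and "open" are said of these compounds alone.

Compound 1 `Nc1ccc(S(=O)(=O)Nc2cccc3c(Cl)c[nH]c23)cc1`: 10 ug/mL
Compound 2 `Nc1ccc(S(=O)(=O)Nc2ccc(Cl)c3c(Cl)c[nH]c23)cc1`: 14 ug/mL

In a functional assay on KB cells (Homo sapiens) for antiproliferative activity, read by colorimetric assay and MTT assay (a higher number here means a weaker inhibitor, a lower number a stronger inhibitor), compound 2 gives 14 ug/mL, which lies within the scatter of compound 1. Compound 3 `Nc1ccc(S(=O)(=O)Nc2ccc(F)c3c(Cl)c[nH]c23)cc1` differs from compound 2 by one swap: fluoro in place of chloro on an aromatic carbon. Within the data shown here, the only measured step that bears on it is a 1.4-fold higher number from compound 1 to compound 2 (0.15 log units; within the scatter), where chloro replaced hydrogen on an aromatic carbon. That step stayed within the scatter, so replacing chloro with fluoro is not expected to move the number beyond the scatter. The expected change is a 1.2-fold lower number from compound 2 to compound 3 (0.07 log units; within the scatter). The estimated value for compound 3 is 12 ug/mL, with an expected range of 6 ug/mL to 25 ug/mL.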

Compound 3, half-maximal inhibitory concentration: 14 ug/mL
The estimate for compound 3 lay 1.2-fold (0.07 log units) below the measured number; measured number inside the range.
By their numbers in this assay, from the lowest: compounds 1, 2 and 3 (each within the scatter of the next).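

In this assay the swap gives no change at the digits printed from compound 2 to compound 3 (within the scatter) so chloro and fluoro cannot be told apart at this position. Fluoro in place of hydrogen gives a 1.4-fold higher number from compound 1 to compound 3 (0.15 log units; within the scatter) and so, like chloro, leaves the number within the scatter of compound 1. No measurement shown offers an explanation for why these groups read alike.

Going by these compounds, whether a different group here, such as an amine, a methoxy or a carboxylic acid, would shift the number remains open. So does whether any change at this position can produce a step beyond the scatter.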